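The source may report more compounds than this note shows. Statements on the series, on what has been measured and on what is new or still open speak of the compounds shown alone.

Three compounds of the series carry measurements in a functional assay on A-431 cells (Homo sapiens) for inhibition, read by MTT assay, with a stated time of 72 h; on this read-out lower numbers stand for stronger inhibition of growth and higher numbers for weaker inhibition of growth. Compound 1 `N#C/C(=C\c1ccc([N+](=O)[O-])cc1)C(=O)c1c[nH]c2ccccc12` gives 46000 nM in this assay. Compound 2 `COc1ccc(CNC(=O)/C(C#N)=C/c2ccc[nH]2)cc1` returns only a limit, > 50000 nM. Compound 3 `N#C/C(=C\c1ccc[nH]1)C(=O)NCc1ccc(Cl)c(Cl)c1` likewise returns a limit, > 50000 nM. For the measured compounds named here, compound 2 thus stands at the limit of > 50000 nM in this assay, at which 2 of the 3 values shown sit, and no step between measured compounds can be counted. Compound 4 `COc1ccc(CNC(=O)/C(C#N)=C/c2ccco2)cc1` is not yet measured; it differs from compound 2 by furan-2-yl in place of 1H-pyrrol-2-yl on a double-bonded chain carbon bound to a double-bonded chain carbon. Going by the values given here, no measured step is available for comparison, so the expected step that the limit leaves unreadable from compound 2 to compound 4 is none beyond the scatter, in either direction. Compound 4 is accordingly estimated to give 60000 nM, within 20000 nM to 200000 nM, and most probably the assay will again report only a limit for it.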

Compound 4, concentration for 50% growth inhibition: 16000 nM
Estimate against measurement, compound 4: 3.8-fold (0.57 log units) above; the whole stated range lies above it.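

In this assay this place responds to the ring it carries: furan-2-yl in place of 1H-pyrrol-2-yl gives an at least 3.1-fold lower number from compound 2 to compound 4 (0.49 log units; beyond the scatter) and yields a measured number in place of a limit. For the compounds shown here, this is the first countable step, but its full size stays open: the limit of > 50000 nM in this assay, at which 2 of the 4 values shown sit. The exchange removes a hydrogen-bond donor and adds an acceptor, and these two changes cannot be separated here. Open, as far as these compounds go, is whether thiophen-2-yl at this place would behave like furan-2-yl, and whether compound 3 would answer the same exchange.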